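A few compounds are considered here, and "the series" means these few. Any claim that something is new, unique, unknown or untested is made for them only; others in the source may bear on it.

Measured so far:
compound 1 `N#CCNC(=O)[C@@H]1CC(F)(F)C[C@H]1C(=O)N1CCOCC1` — 830 nM
compound 2 `N#CCNC(=O)[C@@H]1C[C@@H](S(=O)(=O)c2ccccc2Cl)C[C@H]1C(=O)N1CCOCC1` — 0.5 nM
compound 3 `N#CC1(NC(=O)[C@@H]2C[C@@H](S(=O)(=O)c3ccccc3)C[C@H]2C(=O)N2CC3CCC(C2)O3)CC1` — 1 nM

In an assay on isolated protein for inhibition of cathepsin S (Homo sapiens), read by fluorescence, with a stated time of 20 min (a higher number here means a weaker inhibitor, a lower number a stronger inhibitor), compound 3 sits second highest of the three numbers. Its nearest neighbour is compound 2, whose value lies within the scatter of that of compound 3; its furthest is compound 1, far higher, beyond the scatter.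

Compound 4 `N#CC1(NC(=O)[C@@H]2C[C@@H](S(=O)(=O)c3ccccc3)C[C@H]2C(=O)N2CCS(=O)(=O)CC2)CC1` is not yet measured. It differs from compound 3 by a group of 8 heavy atoms (4 carbon, 1 nitrogen, 2 oxygen, 1 sulfur; one six-membered non-aromatic ring with 2 hetero atoms) in place of a group of 8 heavy atoms (6 carbon, 1 nitrogen, 1 oxygen; one five-membered non-aromatic ring with 1 hetero atom, one six-membered non-aromatic ring with 2 hetero atoms), on a carbonyl carbon.

Among the compounds with values here, no measured step of this kind is available. Compound 2, which carries a six-membered saturated amide ring with two hetero atoms, gives 0.5 nM in this assay, so a change of this sort is not expected to move the number beyond the scatter. The step from compound 3 to compound 4 is estimated at a 1.5-fold higher number from compound 3 to compound 4 (0.18 log units; within the scatter). Compound 4 is therefore expected near 1.5 nM, within 0.5 nM to 5 nM.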

Compound 4, half-maximal inhibitory concentration: 4 nM
Compound 4: middle estimate off by 2.7-fold (0.43 log units), on the low side; the range from low to high includes it.
By their numbers in this assay, from the lowest: compounds 2 and 3 (each within the scatter of the next); then compound 4; then compound 1.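

Within the data shown here, on the carbonyl carbon, 1,1-dioxothiomorpholin-4-yl in place of the group in compound 3 gives a 4.0-fold higher number from compound 3 to compound 4 (0.60 log units; beyond the scatter) in this assay, the first one-place comparison. The position therefore responds measurably to this exchange, though the step is modest. Nothing available bears on the reason for the step.

Still open, from the compounds shown here alone, is how a piperazine ring on the same carbonyl carbon would read. Going by these compounds, it is also open whether this step would keep its size with a different sulfonyl group on the shared core.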